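Shortening the Acid Side Chain in a Receptor Antagonist Series

The compounds below may be only part of what the source reports. "The series", "measured", "known", "first", "only" and "open" are said of these compounds alone.

Measured compounds:
Compound 1, `CCC(C(=O)O)c1nn(Cc2cn3cc(OCC4CC4)c(Cl)cc3n2)c2ccccc2c1=O`: 5.6 nM
Compound 2, `C[C@H](C(=O)O)n1nc(Cn2cc3cc(OCC4CC4)c(Cl)cc3n2)c2ccccc2c1=O`: 3.5 nM

Of the compounds shown here, two have been tested in a functional assay on HFL1 cells for antagonist activity at sphingosine 1-phosphate receptor 2 (Homo sapiens), read by ELISA, with a stated time of 24 h; on this read-out higher numbers stand for weaker inhibition and lower numbers for stronger inhibition. Compound 1 gives the highest of the two numbers in this assay, with compound 2 3.5 nM standing a short way lower, a gap that lies within the scatter, so the two cannot be ordered against each other. Within the data shown here, the two compounds share a core but differ in more than one place, so no single step between them can be read.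

Compound 3, `C[C@H](C(=O)O)c1nn(Cc2cn3cc(OCC4CC4)c(Cl)cc3n2)c2ccccc2c1=O`, has not yet been measured. It differs from compound 1 in one place: 1-carboxyethyl in place of 1-carboxypropyl on an aromatic carbon. Among the measured compounds shown here, the change is small and the acid group is kept, and nothing among the measured pairs speaks for a large shift. The step from compound 1 to compound 3 in this assay is therefore expected to stay within the scatter, a 1.1-fold lower number from compound 1 to compound 3 (0.05 log units; within the scatter). Compound 3 is estimated at 5 nM, with a range from 2 nM to 12 nM.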

Compound 3, half-maximal inhibitory concentration in the sphingosine 1-phosphate receptor 2 assay: 2.1 nM
Estimate against measurement, compound 3: 2.4-fold (0.38 log units) above; measured number inside the range.
By their numbers in the sphingosine 1-phosphate receptor 2 assay, from the lowest: compounds 3, 2 and 1 (each within the scatter of the next, the first and the last beyond it).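

In the sphingosine 1-phosphate receptor 2 assay, 1-carboxyethyl in place of 1-carboxypropyl on this aromatic carbon gives a 2.7-fold lower number from compound 1 to compound 3 (0.43 log units; beyond the scatter), so a small trim of the side chain is felt at this position, which the earlier pair, differing in more than one place, could not show. In a physicochemical assay for solubility, measured as thermodynamic solubility, at pH 7.4 (on this read-out lower numbers stand for lower solubility and higher numbers for higher solubility), compound 1 gives 359 ug/mL and compound 3 gives 892 ug/mL. The same single change therefore moves both read-outs in a favourable direction, with stronger inhibition and a measured gain in solubility: the measured solubility of compound 1, 359 ug/mL, and of compound 3, 892 ug/mL, a 2.5-fold higher number (0.40 log units; beyond the scatter)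

The 1-carboxyethyl group of compound 3 has a defined stereocentre and the 1-carboxypropyl group of compound 1 has none, so this step cannot separate chain length from that stereocentre. On these data alone, whether the mirror-image 1-carboxyethyl group or a shorter carboxymethyl group would behave the same way stays open.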